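The source may hold more compounds than are shown below. What is called first, only, known or untested is meant among the compounds shown, and "the series" means these compounds.

Measured compounds, lipophilicity:
- compound 1 `Cc1ccc(/C=C2\CCC/C(=C\c3ccccc3[N+](=O)[O-])C2=O)cc1`: 4.86
- compound 2 `Cc1ccc(/C=C2\CCC/C(=C\c3ccc([N+](=O)[O-])cc3)C2=O)cc1`: 5.08
- compound 3 `O=C1/C(=C/c2ccc(Cl)cc2)CCC/C1=C\c1cccc([N+](=O)[O-])c1`: 5.06

In a physicochemical assay for lipophilicity (on this read-out lower numbers stand for lower lipophilicity and higher numbers for higher lipophilicity), compound 1 gives the smallest of the three numbers, but its gaps to compound 3 and to compound 2 both lie within the scatter, so the three are not separated by this assay. Among the measured compounds shown here, no pair among them differs in only one place, so no single-change step has been measured.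

Compound 4 `O=C1/C(=C/c2ccccc2)CCC/C1=C\c1ccccc1[N+](=O)[O-]` is yet to be measured. It differs from compound 1 by hydrogen in place of methyl on an aromatic carbon. Removing a carbon with no donor or acceptor is expected to lower this assay modestly, beyond the scatter. The expected step is a number 0.50 log units lower from compound 1 to compound 4 (beyond the scatter). For compound 4 the estimate is 4.36, in the range 4 to 4.7.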

Compound 4, partition coefficient: 4.86
Beside the measured number, compound 4's estimate is 0.50 log units below it; the measured number lies above the stated range.
By their numbers in this assay, from the lowest: compounds 1, 4, 3 and 2 (each within the scatter of the next).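

Among the compounds shown here, this is the first single-change step: in this assay, hydrogen in place of methyl on an aromatic carbon, para to a large group, gives no change at the digits printed from compound 1 to compound 4 (within the scatter). At this place, going from 4-methylphenyl to phenyl therefore does not separate the two compounds on this read-out. No measured data on hand account for this result. Still open, from the compounds shown here alone, is whether an amine, a carboxylic acid or a longer chain at the same place would give a step beyond the scatter, and whether the methyl-to-hydrogen change gives a similar step on compound 2.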